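The compounds below may be only part of what the source reports. "The series", "measured", "known", "first", "only" and "open" are said of these compounds alone.

Measured so far:
Compound 1 `COc1cc(O)cc(O)c1C(=O)/C=C/c1ccc(C(F)(F)F)cc1`: 17100 nM
Compound 2 `COc1cc(O)cc(O)c1C(=O)/C=C/c1ccccc1Br`: 14600 nM
Compound 3 `C=CCOc1cc(OC)c(C(=O)/C=C/c2ccc([N+](=O)[O-])cc2)c(OCC=C)c1`: 13200 nM

All three compounds were examined in a toxicity assay on cells (Macrophage, Mus musculus, strain BALB/c) for cytotoxicity, read by MTT assay; on this read-out higher numbers stand for weaker inhibition and lower numbers for stronger inhibition. Compound 2 gives 14600 nM, a number that sits between the other two, yet its gap to compound 3 and its gap to compound 1 both lie within the scatter, so nothing separates the three beyond repeat variation.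

The unmeasured compound 4 `COc1cc(O)cc(O)c1C(=O)/C=C/c1ccco1` differs from compound 2 by furan-2-yl in place of 2-bromophenyl on a double-bonded chain carbon bound to a double-bonded chain carbon. Going by the values given here, since no single-point step between measured compounds is available, the expected direction rests on the observation that three different aryl groups on the chain all gave numbers within the scatter of one another. The step of a 1.1-fold higher number from compound 2 to compound 4 (0.04 log units; within the scatter) is therefore expected to be small, with no clear direction beyond the scatter. For compound 4 in this assay the estimate is 16000 nM, with a range from 7000 nM to 36000 nM.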

Compound 4, half-maximal inhibitory concentration: 384000 nM
Estimate against measurement, compound 4: 24-fold (1.38 log units) below, and the stated range ends below it.
By their numbers in this assay, from the lowest: compounds 3, 2 and 1 (each within the scatter of the next); then compound 4.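

In this assay, furan-2-yl in place of 2-bromophenyl on a double-bonded chain carbon bound to a double-bonded chain carbon gives a 26-fold higher number from compound 2 to compound 4 (1.42 log units; beyond the scatter), so the group at this place can move the number well beyond the scatter. The earlier compounds shown here, none a single change from another, could not show this. Nothing at hand accounts for the step.

Still open, from the compounds shown here alone, is whether the step follows the loss of the bromine or the arrival of the furan ring. Going by these compounds, whether a plain phenyl or a thiophen-2-yl group here would stand with compound 2 or with compound 4 also remains unknown.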